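This account rests on a few compounds, and the source may have more. Where it says the series, first, only, none or still open, it means among the compounds named here.

Compound 3 `Cc1nc(NC(C2CC2)C2CC2)c2nc(C)n(-c3ccc(Cl)cc3)c2n1` gives 11 nM in a functional assay on CHO cells for antagonist activity at corticotropin-releasing factor receptor 1 (Homo sapiens), read by cAMP accumulation (on this read-out higher numbers stand for weaker inhibition and lower numbers for stronger inhibition), the lowest of the three numbers obtained so far. Compound 1 `COc1ccc(-n2c(C)nc3c(NC(C4CC4)C4CC4)nc(C)nc32)c(C)c1` gives 14 nM, and a 1.3-fold lower number from compound 1 to compound 3 (0.10 log units; within the scatter), so these two cannot be ordered. Compound 2 `Cc1nc(NC(C2CC2)C2CC2)c2nc(C)n(-c3ccc(C#N)cc3)c2n1` gives 62 nM; a 4.4-fold higher number from compound 1 to compound 2 (0.65 log units; beyond the scatter), and a 5.6-fold lower number from compound 2 to compound 3 (0.75 log units; beyond the scatter). Among the measured compounds shown here, the only clear steps in the set thus come from the substituent on the phenyl attached to the aromatic nitrogen of the shared core.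

Compound 4 `Cc1nc(NC(C2CC2)C2CC2)c2nc(C)n(-c3ccc(OC(F)(F)F)cc3)c2n1` differs from compound 3 by trifluoromethoxy in place of chloro on an aromatic carbon. For the measured compounds named here, the steps that bear on this are those on the same ring: a 5.6-fold lower number from compound 2 to compound 3 (0.75 log units; beyond the scatter) and a 1.3-fold lower number from compound 1 to compound 3 (0.10 log units; within the scatter). Chloro and 4-methoxy-2-methylphenyl sit within the scatter of each other, cyano stands apart. Going by the values given here, no measured compound carries a trifluoromethoxy, so the direction is open; a step of no more than modest size is expected, most likely within the scatter, a 1.4-fold higher number from compound 3 to compound 4 (0.13 log units; within the scatter). Compound 4 is therefore expected at 15 nM, within 6 nM to 40 nM.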

Compound 4, inhibition constant: 9 nM
Beside the measured number, compound 4's estimate is 1.7-fold (0.22 log units) above it; the measured number falls inside the stated range.
By their numbers in this assay, from the lowest: compounds 4, 3 and 1 (each within the scatter of the next); then compound 2.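

In this assay, the entry of trifluoromethoxy with its five heavy atoms for the single chlorine, on an aromatic carbon para to a large group, gives no resolved change: a 1.2-fold lower number from compound 3 to compound 4 (0.09 log units; within the scatter). The same group clearly separates from cyano, a 6.9-fold lower number from compound 2 to compound 4 (0.84 log units; beyond the scatter), so of the three groups compared directly at this place, only cyano stands apart, while the much larger trifluoromethoxy is accommodated without a resolved loss against chloro. No measurement on these compounds accounts for the gap between cyano and the other two groups.

Going by these compounds, whether the gap seen with cyano extends to other groups at this place, such as an amine or a carboxylic acid, remains open. All the compounds shown keep the dicyclopropylmethyl amino group, so the effect of a longer chain in its place is also open.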